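This account rests on a few compounds, and the source may have more. Where it says the series, first, only, none or still open, it means among the compounds named here.

Working notes on the series. The shared core of compound 1 `COc1ccc(/C=N/NC(=O)c2ccc(N)cc2)cc1` carries, in compound 2 `COc1ccc(/C=N/NC(=O)c2ccc(N)cc2)cc1OC`, an added methoxy group; in a physicochemical assay for lipophilicity (a lower number here means a more polar compound, a higher number a more lipophilic compound), compound 1 gives 2.39 and compound 2 gives 2.14. For the measured compounds named here, the only measured step, a number 0.25 log units lower from compound 1 to compound 2 (within the scatter), leaves compound 2 with the lower of the two numbers, though the gap to compound 1 stays within the scatter.

Compound 3 `COc1ccc(/C=N/NC(=O)c2ccc(Cl)cc2)cc1OC` is not yet measured. The change from compound 2 to compound 3 is chloro in place of amino on an aromatic carbon. Going by the values given here, no measured step bears on this change: the step from compound 1 to compound 2 concerns a methoxy group and says nothing about an amino-to-chloro exchange. The expectation therefore rests on the counted difference alone, which removes one hydrogen-bond donor and one hydrogen-bond acceptor, so a rise of a number 1.16 log units higher from compound 2 to compound 3 (beyond the scatter) in this assay is expected. For compound 3 the estimate is 3.3, within 2.8 to 3.9.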

Compound 3, partition coefficient: 3.44
Compound 3: middle estimate off by 0.14 log units, on the low side; low and high end bracket the measured number.
By their numbers in this assay, from the lowest: compounds 2 and 1 (each within the scatter of the next); then compound 3.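

For the compounds shown here, the amino-to-chloro exchange gives the only step that lies beyond the scatter: in this assay the number moves a number 1.30 log units higher from compound 2 to compound 3 (beyond the scatter) and sets compound 3 apart from the other two compounds. This shows that the group on the aromatic carbon para to a large group can move the read-out far more than the added methoxy group did, whose step stayed within the scatter. Nothing measured here explains the size of this step.

A single exchange cannot separate what leaving amino contributes from what entering chloro contributes; methyl, hydroxyl or bromo at this position would bear on that. From the compounds shown here alone, whether the same exchange gives a step of similar size on the core of compound 1, without the added methoxy group, also remains open.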